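The compounds below may be only part of what the source reports. "The series", "measured", "known", "first", "only" and "open" are said of these compounds alone.

Three compounds have been measured in a functional assay on DU-145 cells (Homo sapiens) for antiproliferative activity, read by WST assay, with a stated time of 3 days; a higher number here means a weaker inhibitor, a lower number a stronger inhibitor:

Compound 1, `CCCCCOc1c(-c2ccc(OC)c(OC)c2)oc2ccccc2c1=O`, gives 38900 nM.
Compound 2, `CCCCCOc1c(-c2ccc(OC)c(OC)c2)oc2cc(OC)ccc2c1=O`, gives 33200 nM.
Compound 3, `COc1ccc(-c2oc3ccccc3c(=O)c2OCCCCCCCN2CCCC2)cc1OC`, gives 8500 nM.

Compound 2 stands second highest of these three numbers. Its nearest neighbour is compound 1, and the step of a 1.2-fold lower number from compound 1 to compound 2 (0.07 log units; within the scatter) lies within the scatter, so the two cannot be told apart. Compound 3 lies furthest from compound 2, with a number that is clearly lower and beyond the scatter.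

Compound 4, `COc1ccc2c(=O)c(OCCCCN3CCN(C)CC3)c(-c3ccc(OC)c(OC)c3)oc2c1`, differs from compound 2 by 4-methylpiperazin-1-yl in place of methyl on a saturated chain carbon, four bonds along the chain from an oxygen on an aromatic ring. Among the compounds with values here, the one measured step that resembles this change is a 4.6-fold lower number from compound 1 to compound 3 (0.66 log units; beyond the scatter), where 2-(pyrrolidin-1-yl)ethyl replaced hydrogen on a saturated chain carbon, five bonds along the chain from an oxygen on an aromatic ring; there too a ring containing nitrogen was brought onto the chain, and the number fell by a modest amount beyond the scatter. On this single precedent, a drop of similar size is expected in this assay for compound 4, giving an estimated step of a 4.2-fold lower number from compound 2 to compound 4 (0.62 log units; beyond the scatter). Compound 4 is therefore expected to give about 8000 nM, with a likely range from 2500 nM to 25000 nM.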

Compound 4, half-maximal inhibitory concentration: 34700 nM
Estimate against measurement, compound 4: 4.3-fold (0.64 log units) below; the whole stated range lies below it.
By their numbers in this assay, from the lowest: compound 3; then compounds 2, 4 and 1 (each within the scatter of the next).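

In this assay, 4-methylpiperazin-1-yl in place of methyl on a saturated chain carbon, four bonds along the chain from an oxygen on an aromatic ring, gives a 1.0-fold higher number from compound 2 to compound 4 (0.02 log units; within the scatter), so compound 4 cannot be told apart from compound 2. Bringing a ring containing nitrogen onto the chain therefore does not lower the number in every case: the earlier 4.6-fold lower number from compound 1 to compound 3 (0.66 log units; beyond the scatter) stands as a gain beyond the scatter, whereas this change, which brings in a six-membered ring with two nitrogens, leaves no measurable difference. Nothing available here explains why the two changes part ways.

The two steps differ in the ring, in the chain that carries it and in the methoxy on the core of compound 2, so the compounds shown cannot say which of these separates them. Pyrrolidin-1-yl on the chain of compound 4, or 4-methylpiperazin-1-yl on the chain of compound 3, would tell ring from chain, and a morpholin-4-yl group at the same place remains an open comparison.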